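Shortening the Chain on the Ring Nitrogen

The source may report more compounds than this note shows. Statements on the series, on what has been measured and on what is new or still open speak of the compounds shown alone.

Measured compounds:
compound 1 `COC(CCn1cnc2c(NCc3ccc(C(=O)Nc4ccccc4N)cc3)nc(Cl)nc21)OC` — 6.39%
compound 2 `CCCCn1cnc2c(NCc3ccc(C(=O)Nc4ccccc4N)cc3)nc(Cl)nc21` — 4.89%

Both compounds share one core and differ only in the chain attached to the aromatic nitrogen. In a functional assay on HCT-116 cells (Homo sapiens) for antiproliferative activity, read by CCK-8 assay, with a stated time of 72 h, tested at 2 uM (on this read-out higher numbers stand for a stronger effect at the one concentration tested and lower numbers for a weaker effect), compound 1 gives 6.39%. In this assay compound 2 gives 4.89%. Among the compounds with values here, compound 2 therefore stands together with compound 1: the one measured step, a number 1.5 percentage points lower from compound 1 to compound 2 (within the scatter), changes the far end of that chain and leaves the read-out essentially where it was. Both numbers are small, meaning little antiproliferative effect at the tested concentration.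

Compound 3 `CC(C)n1cnc2c(NCc3ccc(C(=O)Nc4ccccc4N)cc3)nc(Cl)nc21` shortens the same chain: isopropyl in place of butyl on an aromatic nitrogen. Within the data shown here, no measured step touches the ring nitrogen directly, so the only guidance is the step from compound 1 to compound 2, which altered the chain further out and stayed within the scatter. On that basis the step of a number 0.6 percentage points higher from compound 2 to compound 3 (within the scatter) is expected to be none beyond the scatter. Compound 3 is thus estimated at 5.5%, with a range from -3% to 16%.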

Compound 3, a percentage reported as inhibition, at one concentration (the size of the read-out at that concentration, not a potency): 73.2%
Beside the measured number, compound 3's estimate is 67.7 percentage points below it, and the stated range ends below it.
By their numbers in this assay, from the lowest: compounds 2 and 1 (each within the scatter of the next); then compound 3.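

In this assay, the chain on the aromatic nitrogen proves to be far from indifferent: isopropyl in place of butyl gives a number 68.3 percentage points higher from compound 2 to compound 3 (beyond the scatter), and isopropyl in place of 3,3-dimethoxypropyl gives a number 66.8 percentage points higher from compound 1 to compound 3 (beyond the scatter). The butyl and 3,3-dimethoxypropyl chains had given no sign of this, as their two numbers lie within the scatter of each other, whereas isopropyl separates clearly from both on an otherwise unchanged core. Nothing available here explains why this one small change in the chain has so large an effect.

Isopropyl differs from butyl in both length and branching, and the compounds shown cannot separate these two features. A straight propyl, a cyclopropyl or a tert-butyl on the same nitrogen would help to tell them apart, while each number remains the size of the effect at a single concentration and not a measure of potency.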